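Swapping a tert-butyl amide for a cyclopentylmethyl urea

This account rests on a few compounds, and the source may have more. Where it says the series, first, only, none or still open, it means among the compounds named here.

Compound 1 `CCCC(=O)Nc1cccc(S(=O)(=O)Oc2ccccc2C(C)C)c1`: 15000 nM
Compound 2 `CC(C)c1ccccc1OS(=O)(=O)c1ccc(NC(=O)C(C)(C)C)cc1`: 11000 nM
Compound 3 `CC(C)(C)C(=O)Nc1ccc(S(=O)(=O)Oc2ccccc2I)cc1`: 2600 nM

These three values come from a functional assay on HT-1080 cells (Homo sapiens) for antiproliferative activity, read by sulforhodamine B assay, with a stated time of 48 h; a lower number here means a stronger inhibitor, a higher number a weaker inhibitor. Compound 2 stands second highest of the three; compound 1 lies nearest, within the scatter, while compound 3 lies furthest, reached by a 4.2-fold lower number from compound 2 to compound 3 (0.63 log units; beyond the scatter). Compound 4 `CC(C)c1ccccc1OS(=O)(=O)c1ccc(NC(=O)NCC2CCCC2)cc1` differs from compound 2 by (cyclopentylmethyl)amino in place of tert-butyl on a carbonyl carbon. Among the compounds with values here, the only measured step changes a group on an aromatic carbon, not the amide end, so no measured step bears on this change. With nothing to guide a direction, the expectation is a change no larger than the scatter. Compound 4 is therefore estimated at 11000 nM, with a range from 4000 nM to 30000 nM. The expected step is no change at the digits printed from compound 2 to compound 4 (within the scatter).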

Compound 4, half-maximal inhibitory concentration: 6000 nM
Beside the measured number, compound 4's estimate is 1.8-fold (0.26 log units) above it; low and high end bracket the measured number.
By their numbers in this assay, from the lowest: compound 3; then compounds 4, 2 and 1 (each within the scatter of the next, the first and the last beyond it).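

At this carbonyl carbon, a bulkier group carrying a ring and a hydrogen-bond donor can replace tert-butyl with no change beyond the scatter in this assay (a 1.8-fold lower number from compound 2 to compound 4 (0.26 log units; within the scatter)). This is the only step shown at this carbonyl carbon, and it turns the amide of compound 2 into a urea while activity stays in the same range. No measurement shown explains this outcome.

On these data alone, whether a smaller methylamino group or an open-chain pentylamino group would behave alike remains open. So does whether iodo in place of isopropyl would lower the number for compound 4 as it did for compound 2.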